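A Fluorine Atom and Cytotoxicity on Breast Cancer Cells

The source may hold more compounds than are shown below. What is called first, only, known or untested is meant among the compounds shown, and "the series" means these compounds.

Of the compounds shown here, three built on one shared core have so far been measured in a functional assay on MCF7 cells (Homo sapiens) for cytotoxicity, read by MTT assay, with a stated time of 24 h; on this read-out higher numbers stand for weaker inhibition and lower numbers for stronger inhibition. Compound 3 `Cc1cc(-c2nc3ccccc3o2)ccc1NC(=O)CCl` carries a chloroacetamide and gives 29800 nM. Compound 1 `Cc1cc(-c2nc3cc(F)ccc3o2)ccc1NC(=O)CCl` is its close relative; in this assay compound 1 gives only a limit, > 100000 nM, not a number. The change from compound 3 to compound 1 is fluoro in place of hydrogen on an aromatic carbon. On these data alone, it made an at least 3.3-fold higher number from compound 3 to compound 1 (0.52 log units; beyond the scatter), and the step stays open at the top because the limit of > 100000 nM in this assay, at which 1 of the 3 values shown sits, caps what can be read.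

Compound 2 `Cc1cc(-c2nc3ccccc3o2)ccc1NC(=O)CN1CCN(CCCN(C)C)CC1` keeps the same aromatic part but carries a longer amine-bearing chain in place of the chloroacetamide; how its core differs from that of compound 3 is not broken down here. In this assay compound 2 gives 11300 nM, the lower of the two numbers, which places it beyond the scatter from compound 3.

Compound 4 `Cc1cc(-c2nc3cc(F)ccc3o2)ccc1NC(=O)CN1CCN(CCCN(C)C)CC1` has not yet been measured. It differs from compound 2 by fluoro in place of hydrogen on an aromatic carbon, the very same change that turned compound 3 into compound 1, at the same place. Since that earlier step was an at least 3.3-fold higher number from compound 3 to compound 1 (0.52 log units; beyond the scatter), a move in the same direction is expected here, though its exact size is uncertain given that the earlier value was a limit. Compound 4 is therefore expected to give about 35000 nM, somewhere between 12000 nM and 150000 nM. The expected step is a 3.1-fold higher number from compound 2 to compound 4 (0.49 log units; beyond the scatter).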

Compound 4, half-maximal inhibitory concentration: 7770 nM
Compound 4: the middle estimate sits 4.5-fold (0.65 log units) above what was measured; the whole stated range lies above it.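

In this assay, the change from 1,3-benzoxazol-2-yl to 5-fluoro-1,3-benzoxazol-2-yl gives a 1.5-fold lower number from compound 2 to compound 4 (0.16 log units; within the scatter), so on the core with the amine-bearing chain, the fluoro makes no difference that can be told from ordinary repeat variation. The change therefore did not carry over from the chloroacetamide core to this one with the same result, and a step seen on one core could not be relied on to predict the step on the other: the same change on two cores in this assay, an at least 3.3-fold higher number (0.52 log units; beyond the scatter) from compound 3 to compound 1 and a 1.5-fold lower number (0.16 log units; within the scatter) from compound 2 to compound 4, at least 4.8-fold (0.68 log units) apart, beyond the scatter of two such steps. These data do not show why the two cores part ways, nor how large the step on the chloroacetamide pair really is, since one end of that pair rests on a limit and not on a number: the limit of > 100000 nM in this assay, at which 1 of the 4 values shown sits.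

Among these compounds, with only two matched pairs, it remains open which of the two outcomes is more typical of the fluoro change across other side chains. Also open, on these data alone, is whether a chloro group in place of the fluoro, or a carboxylic acid in place of the amine at the end of the chain, would behave in the same way on each core.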